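The source may hold more compounds than are shown below. What is called first, only, known or untested is meant among the compounds shown, and "the series" means these compounds.

Measured so far in a toxicity assay on MCF-10A cells (Homo sapiens) for inhibition, read by MTT assay, with a stated time of 72 h; on this read-out higher numbers stand for weaker inhibition of growth and lower numbers for stronger inhibition of growth: compound 1 `O=S(=O)(NCCCCNCc1ccc(Br)cc1)c1cc(C(F)(F)F)cc(C(F)(F)F)c1` gives 3200 nM; compound 2 `CC(C)(C)c1ccc(CNCCCNS(=O)(=O)c2cc(C(F)(F)F)cc(C(F)(F)F)c2)cc1` gives 3200 nM; compound 3 `COc1cccc(CNCCCNS(=O)(=O)c2cc(C(F)(F)F)cc(C(F)(F)F)c2)c1` gives 6600 nM.

Compound 3 stands with the highest of the three numbers, the weakest inhibition of growth shown here, since both a 2.1-fold higher number from compound 1 to compound 3 (0.31 log units; beyond the scatter) and a 2.1-fold higher number from compound 2 to compound 3 (0.31 log units; beyond the scatter) lie beyond the scatter. Compound 4 `O=S(=O)(NCCCNCc1cccc(Cl)c1)c1cc(C(F)(F)F)cc(C(F)(F)F)c1` differs from it by one change: chloro in place of methoxy on an aromatic carbon. The two measured steps both arrive at the methoxy-bearing compound 3 with a modest rise in number, and one of them starts from a compound carrying a halogen. The step to compound 4 runs the other way, bringing in a halogen, so a modest fall in this assay is expected, a 1.9-fold lower number from compound 3 to compound 4 (0.28 log units; within the scatter). Compound 4 is therefore estimated at 3500 nM, with a range from 1700 nM to 7000 nM.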

Compound 4, concentration for 50% growth inhibition: 7000 nM
Compound 4: middle estimate off by 2.0-fold (0.30 log units), on the low side; measured number inside the range.
By their numbers in this assay, from the lowest: compounds 1 and 2 (each within the scatter of the next); then compounds 3 and 4 (each within the scatter of the next).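

In this assay, chloro in place of methoxy on this aromatic carbon, meta to a large group, makes no readable difference, with a 1.1-fold higher number from compound 3 to compound 4 (0.03 log units; within the scatter). Compound 4 stays with compound 3, apart from the other two by a 2.2-fold higher number from compound 2 to compound 4 (0.34 log units; beyond the scatter) and by a 2.2-fold higher number from compound 1 to compound 4 (0.34 log units; beyond the scatter), so a halogen alone does not bring the lower numbers of compound 1 and compound 2. No measured evidence bears on this result. The compounds shown leave open whether fluoro, methyl or a nitrile on this same carbon would also stay level with compound 3, and how chloro would read elsewhere on the ring.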